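From nitrile to tetrazole in a cytotoxicity screen

This account rests on a few compounds, and the source may have more. Where it says the series, first, only, none or still open, it means among the compounds named here.

Compound 1 `O=c1[nH]cc(-c2ccc(F)cc2)cc1O` and compound 2 `N#Cc1ccc(-c2c[nH]c(=O)c(O)c2)cc1` share one core and differ only in the group on the carbon ring. In an ADME assay on MDCK cells (Canis lupus familiaris) for cytotoxicity, read by MTT assay, with a stated time of 4 days (on this read-out lower numbers stand for stronger inhibition and higher numbers for weaker inhibition), compound 1 reaches only the assay limit > 100000 nM. In this assay compound 2 likewise gives the assay limit > 100000 nM. The step that the two limits leave unreadable from compound 1 to compound 2 is therefore unreadable, since both values sit at the limit of > 100000 nM in this assay, at which 2 of the 2 values shown sit. Compound 3 `O=c1[nH]cc(-c2ccc(-c3nnn[nH]3)cc2)cc1O` carries 1H-tetrazol-5-yl in place of cyano on an aromatic carbon. For the measured compounds named here, no measured step reads, so the only guide is that compound 2 stands at the limit. Compound 3 is expected to remain near that limit, with a step that the limit leaves unreadable from compound 2 to compound 3 no larger than the scatter and an estimate of 120000 nM between 50000 nM and 300000 nM.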

Compound 3, half-maximal inhibitory concentration: > 100000 nM
Compound 3: only a limit was reported; the forecaster's own chance of this, stated with the estimate: 85%; the middle value does not contradict the limit.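

In this assay compound 3 gives > 100000 nM, which is a limit. For the compounds shown here, no step among compound 1, compound 2 and compound 3 can therefore be read: the limit of > 100000 nM in this assay, at which 3 of the 3 values shown sit. These compounds leave open whether the group on the carbon ring changes the read-out at all.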